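A few compounds are considered here, and "the series" means these few. Any claim that something is new, unique, unknown or untested is made for them only; others in the source may bear on it.

Compound 1 `COc1c(C(=O)/C=C/c2ccc(Cl)cc2)c(O)c(Br)c2occc12`: 3220 nM
Compound 2 `C=CCc1c(O)c(C(=O)/C=C/c2ccccc2)c(OC)c2ccoc12`: 2360 nM

In a functional assay on U-251 cells (Homo sapiens) for inhibition, with a stated time of 48 h (a higher number here means a weaker inhibitor of growth, a lower number a stronger inhibitor of growth), compound 1 and compound 2 lie within the scatter of each other, so compound 2 at 2360 nM cannot be ranked apart from compound 1. Compound 3 `C=CCc1c(O)c(C(=O)/C=C/c2ccc(Cl)cc2)c(OC)c2ccoc12` is compound 2 with chloro in place of hydrogen on an aromatic carbon, para to a large group, turning phenyl into 4-chlorophenyl: chloro in place of hydrogen on an aromatic carbon. Among the compounds with values here, no measured pair isolates this change, so no step beyond the scatter is expected. The expected change is a 1.2-fold lower number from compound 2 to compound 3 (0.07 log units; within the scatter). The estimate for compound 3 is 2000 nM, with an expected range of 800 nM to 4500 nM.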

Compound 3, concentration for 50% growth inhibition: 2300 nM
Beside the measured number, compound 3's estimate is 1.2-fold (0.06 log units) below it; the measured number falls inside the stated range.
By their numbers in this assay, from the lowest: compounds 3, 2 and 1 (each within the scatter of the next).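

In this assay, within the data shown here, the change from phenyl to 4-chlorophenyl gives a 1.0-fold lower number from compound 2 to compound 3 (0.01 log units; within the scatter) and is the first isolated reading of chloro in place of hydrogen on this aromatic carbon. Among these compounds, with 4-chlorophenyl held fixed, allyl in place of bromo on an aromatic carbon gives a 1.4-fold lower number from compound 1 to compound 3 (0.15 log units; within the scatter) and likewise yields no separable step. No measurement here bears on the reason for either result. Going by these compounds, whether an amine or a carboxylic acid in place of chloro, or a longer chain in place of allyl, would give a step beyond the scatter remains open.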